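The compounds below may be only part of what the source reports. "The series", "measured", "known", "first", "only" and "open" are said of these compounds alone.

In a functional assay on K562 cells (Homo sapiens), read by MTT assay, with a stated time of 72 h (a higher number here means a weaker inhibitor, a lower number a stronger inhibitor), compound 3 `Nc1nc2c(c(-c3ccoc3)cn2[C@@H]2O[C@H](CO)[C@@H](O)[C@H]2O)c(=O)[nH]1` gives 12500 nM. Compound 1 `Nc1nc2c(c(-c3ccco3)cn2[C@@H]2O[C@H](CO)[C@@H](O)[C@H]2O)c(=O)[nH]1` differs from compound 3 in one place, (furan-2-yl in place of furan-3-yl on an aromatic carbon), and the step it made is an at least 1.6-fold higher number from compound 3 to compound 1 (0.20 log units; that floor lies within the scatter). For compound 1 the value in this assay, > 20000 nM, is a limit of the assay and not a number. That the step can only be given as a floor rests on (the limit of > 20000 nM in this assay, at which 2 of the 3 values shown sit).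

Compound 2 `COc1nc(N)nc2c1c(-c1ccoc1)cn2[C@@H]1O[C@H](CO)[C@@H](O)[C@H]1O` has a different core from compound 3, and the difference between the two cores is not broken down here. In this assay compound 2 gives > 20000 nM, which is again a limit of the assay and not a number.

Compound 4 `COc1nc(N)nc2c1c(-c1ccco1)cn2[C@@H]1O[C@H](CO)[C@@H](O)[C@H]1O` has not been measured in this assay. It differs from compound 2 in one place, (furan-2-yl in place of furan-3-yl on an aromatic carbon), and the place around the change is the same in its printed words as for the pair of compound 3 and compound 1, so it is the same change. That change made the step of an at least 1.6-fold higher number from compound 3 to compound 1 (0.20 log units; that floor lies within the scatter), and since the value of compound 2 is itself a limit, compound 4 is expected to give no better than that; the step from compound 2 to compound 4 is estimated as a step that the limit leaves unreadable from compound 2 to compound 4. Compound 4 is therefore expected to give about 40000 nM in this assay, between 15000 nM and 150000 nM, most likely reported only as a limit again.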

Compound 4, half-maximal inhibitory concentration: > 20000 nM
Compound 4 was reported as a limit (the forecaster's own chance of this, stated with the estimate: 85%); the middle value lies beyond the limit too.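

In this assay compound 4 gives > 20000 nM as a limit of the assay and not a number. Within the data shown here, no step from compound 2 to compound 4 can be read, because both compounds stand at the same limit: (the limit of > 20000 nM in this assay, at which 3 of the 4 values shown sit). The compounds shown leave open how far furan-2-yl in place of furan-3-yl moves the value on the core of compound 2, or whether it moves it at all.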